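Swapping the aryl group on the ring nitrogen of compound 3

This account rests on a few compounds, and the source may have more. Where it says the series, first, only, none or still open, it means among the compounds named here.

The series shares one core and varies the aryl group on the ring nitrogen and the alkyl on the amide. Compound 2 `CCNC(=O)c1cc(Oc2ccc(NC(=O)c3cc4cccnc4n(-c4ccccc4)c3=O)cc2)ccn1` gives 220 nM in a functional assay on HT-29 cells (Homo sapiens) for antiproliferative activity, read by MTT assay, with a stated time of 72 h (on this read-out lower numbers stand for stronger inhibition and higher numbers for weaker inhibition), compound 1 `CNC(=O)c1cc(Oc2ccc(NC(=O)c3cc4cccnc4n(-c4ccc(Br)cc4F)c3=O)cc2)ccn1` gives 1950 nM, and compound 3 `CCNC(=O)c1cc(Oc2ccc(NC(=O)c3cc4cccnc4n(-c4ccc(OC)cc4)c3=O)cc2)ccn1` gives 3350 nM. On these numbers compound 3 has the highest value, sitting closest to compound 1 and furthest from compound 2. Within the data shown here, the one measured step that touches the aryl group is a 15-fold higher number from compound 2 to compound 3 (1.18 log units; beyond the scatter), which shows that a change at this position can move the read-out strongly.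

Compound 4 `CCNC(=O)c1cc(Oc2ccc(NC(=O)c3cc4cccnc4n(-c4ccc(Br)cc4F)c3=O)cc2)ccn1` is obtained from compound 3 by 4-bromo-2-fluorophenyl in place of 4-methoxyphenyl on an aromatic nitrogen. Among the measured compounds shown here, no measured step covers this exact exchange. Compound 1 carries the same 4-bromo-2-fluorophenyl group, differing from compound 4 only in its methyl rather than ethyl amide, and its value lies close to that of compound 3 rather than to that of compound 2. The expected step is therefore a modest lowering, a 2.6-fold lower number from compound 3 to compound 4 (0.41 log units; beyond the scatter), with the uncertainty from the amide difference left open. Compound 4 is estimated at 1300 nM, within a range from 350 nM to 4500 nM.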

Compound 4, half-maximal inhibitory concentration: 2070 nM
Compound 4: middle estimate off by 1.6-fold (0.20 log units), on the low side; measured number inside the range.
By their numbers in this assay, from the lowest: compound 2; then compounds 1, 4 and 3 (each within the scatter of the next).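

In this assay, the exchange of 4-methoxyphenyl for 4-bromo-2-fluorophenyl on the aromatic nitrogen gives a 1.6-fold lower number from compound 3 to compound 4 (0.21 log units; within the scatter), so these two quite differently substituted aryl groups cannot be told apart on this read-out. Both stand apart from the plain phenyl group: beside the earlier 15-fold higher number from compound 2 to compound 3 (1.18 log units; beyond the scatter), the new exchange gives a 9.4-fold higher number from compound 2 to compound 4 (0.97 log units; beyond the scatter), so with the ethyl amide both substituted rings shown carry a clear penalty against phenyl, and no compound shown goes against this. The series also now holds its first pair differing only in the amide alkyl, and with 4-bromo-2-fluorophenyl on the ring nitrogen that change gives a 1.1-fold higher number from compound 1 to compound 4 (0.03 log units; within the scatter), so the ethyl and methyl amides cannot be told apart with this aryl group.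

The compounds shown leave open whether a lone fluorine, a lone bromine or an amino group on the phenyl ring would stay near compound 2 or fall with compound 3 and compound 4, and whether the methyl amide would match the ethyl amide with a plain phenyl group. No supporting evidence accompanies these numbers, and the reason for the gap from phenyl stays unexplained.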